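From Methyl to Nitro: Compound 3 and Compound 4

This account rests on a few compounds, and the source may have more. Where it says the series, first, only, none or still open, it means among the compounds named here.

In a functional assay on KB cells (Homo sapiens) for inhibition (on this read-out higher numbers stand for weaker inhibition and lower numbers for stronger inhibition), compound 1 `Nc1nc2cc(Cl)c(Cl)cc2n1Cc1ccccc1` gives 170000 nM and stands highest of the three measured compounds. Chloro in place of hydrogen on an aromatic carbon leads to compound 2 `Nc1nc2cc(Cl)c(Cl)cc2n1Cc1ccc(Cl)cc1` at 45000 nM and the change is a 3.8-fold lower number from compound 1 to compound 2 (0.58 log units; beyond the scatter) and counts as modest. A methyl group where compound 1 has a hydrogen leads to compound 3 `Cc1cccc(Cn2c(N)nc3cc(Cl)c(Cl)cc32)c1` at 65000 nM and the change of a 2.6-fold lower number from compound 1 to compound 3 (0.42 log units; beyond the scatter) is also modest. Compound 3 thus lies clearly under compound 1 and within the scatter of compound 2.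

The next compound, compound 4 `Nc1nc2cc(Cl)c(Cl)cc2n1Cc1cccc([N+](=O)[O-])c1`, carries nitro in place of methyl on an aromatic carbon, meta to a large group (nitro in place of methyl on an aromatic carbon). For the measured compounds named here, no measured compound carries a nitro, so the data give only indirect guidance on this swap. Still, compound 2 at 45000 nM shows that a group other than methyl can land within the scatter of compound 3, and both measured steps were modest. No step beyond the scatter is therefore expected in this assay and the estimated change is a 1.1-fold lower number from compound 3 to compound 4 (0.03 log units; within the scatter) with either direction possible. Compound 4 is expected at 60000 nM (estimated range 25000 nM to 140000 nM).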

Compound 4, half-maximal inhibitory concentration: 65000 nM
Estimate against measurement, compound 4: 1.1-fold (0.03 log units) below, and the stated range covers the measured number.
By their numbers in this assay, from the lowest: compounds 2, 3 and 4 (each within the scatter of the next); then compound 1.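

At this place on the six-membered aromatic ring of carbon only, nitro brings in three heavy atoms and two hydrogen-bond acceptors where methyl has one heavy atom and no acceptors, yet this assay shows no change at the digits printed from compound 3 to compound 4 (within the scatter) for this swap. Measured against the hydrogen of compound 1, the two groups give matching steps, with a 2.6-fold lower number from compound 1 to compound 3 (0.42 log units; beyond the scatter) for methyl and a 2.6-fold lower number from compound 1 to compound 4 (0.42 log units; beyond the scatter) for nitro, so in these compounds a clear difference in the group's atoms and acceptor count does not appear in the read-out. The data offer no measured information that would explain this match.

From the compounds shown here alone, whether an amine, a carboxylic acid or a longer chain at this same place would stay within the scatter of compound 3 and compound 4 or move away from them remains open. Also open, going by these compounds, is whether nitro would give the same result at another place on the ring, since these compounds show it in only one.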